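Ethoxy in Place of Ethyl: An Expected Step

This account rests on a few compounds, and the source may have more. Where it says the series, first, only, none or still open, it means among the compounds named here.

Three compounds share one core, and compound 2 `CCc1ccc(NC2=CC(=O)c3nc4n(c3C2=O)[C@H]2OC[C@@H](O)[C@H]2OC4)cc1` is the only one of them for which a functional assay on ECa-109 cells for inhibition, with ECa-109 cell line (Homo sapiens) as the target, read by sulforhodamine B assay (a lower number here means a stronger inhibitor, a higher number a weaker inhibitor), returns a number: compound 2 gives 3080 nM. Compound 1 `O=C1C(N2CCCCC2)=CC(=O)c2c1nc1n2[C@H]2OC[C@@H](O)[C@H]2OC1`, which carries piperidin-1-yl on the double-bonded ring carbon, gives in this assay only a limit, > 8000 nM. Compound 3 `Cc1ccc(NC2=CC(=O)c3c(nc4n3[C@H]3OC[C@@H](O)[C@H]3OC4)C2=O)cc1` gives in this assay likewise only a limit, > 4000 nM. Hence the single measured step, a step that the two limits leave unreadable from compound 1 to compound 3, cannot be read in size, as the two limits the limit of > 4000 nM in this assay, at which 1 of the 3 values shown sits, and the limit of > 8000 nM in this assay, at which 1 of the 3 values shown sits, show.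

Compound 4 `CCOc1ccc(NC2=CC(=O)c3nc4n(c3C2=O)[C@H]2OC[C@@H](O)[C@H]2OC4)cc1` differs from compound 2 in one place: ethoxy in place of ethyl on an aromatic carbon. Going by the values given here, no measured step touches this change, and the one step that exists, a step that the two limits leave unreadable from compound 1 to compound 3, is itself unreadable, so there is nothing in the data that points to a direction for it. Absent any such guidance, the change is expected to leave the potency within the usual scatter of this assay. Compound 4 is therefore estimated at 3000 nM in this assay, with a range from 1000 nM to 9000 nM. The step of a 1.0-fold lower number from compound 2 to compound 4 (0.01 log units; within the scatter) is expected to stay within scatter, though the estimate is uncertain.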

Compound 4, half-maximal inhibitory concentration: 3210 nM
Estimate against measurement, compound 4: 1.1-fold (0.03 log units) below, within the range that was stated.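

In this assay, replacing ethyl with ethoxy on an aromatic carbon para to a large group gives a 1.0-fold higher number from compound 2 to compound 4 (0.02 log units; within the scatter), so compound 2 and compound 4 cannot be told apart at this position, even though the ethoxy group brings an oxygen and a hydrogen-bond acceptor that ethyl lacks. This is the only readable step among the compounds shown, as the earlier step ended on limits and gave no size, and it is the first evidence at this position that 4-ethylphenyl and 4-ethoxyphenyl sit within the scatter of each other. Nothing measured here offers a cause for this result.

For compound 3, > 4000 nM is a limit and not a number. As far as these compounds go, it remains open whether a longer chain such as butoxy, an amine or a carboxylic acid at this same position would stay within the scatter of compound 2 or move away from it, since this single pair speaks only for ethyl and ethoxy.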